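Working notes: from compound 3 to compound 4

The source may hold more compounds than are shown below. What is called first, only, known or untested is meant among the compounds shown, and "the series" means these compounds.

Values in an ADME assay on L6 cells (Rattus norvegicus) for cytotoxicity, read by resazurin assay, with a stated time of 72 h; a higher number here means a weaker inhibitor, a lower number a stronger inhibitor:
Compound 1 `CN1CCN(CC(=O)OC2CC3(N(C)C)CC(c4ccccc4)C2C(c2ccccc2)C3)CC1`: 39900 nM
Compound 2 `CN1CCN(CC(=O)OC2CC3(N4CCCC4)CC(c4ccccc4)C2C(c2ccccc2)C3)CC1`: 24600 nM
Compound 3 `CN1CCN(CCC(=O)NC2CC3(N4CCCCC4)CC(c4ccccc4)C2C(c2ccccc2)C3)CC1`: 61100 nM

Compound 3 stands at 61100 nM within the scatter of compound 1 and beyond the scatter from compound 2, whose number is lower. Compound 4 `CN1CCN(CC(=O)OC2CC3(N4CCCCC4)CC(c4ccccc4)C2C(c2ccccc2)C3)CC1` carries (((4-methylpiperazin-1-yl)methyl)carbonyl)oxy in place of ((2-(4-methylpiperazin-1-yl)ethyl)carbonyl)amino on a saturated ring carbon. Going by the values given here, no measured step covers this exchange. The only one available, a 1.6-fold lower number from compound 1 to compound 2 (0.21 log units; within the scatter) for pyrrolidin-1-yl in place of dimethylamino, lies within the scatter and joins two compounds that already carry the entering group. Compound 4 is therefore expected to sit near compound 1 at 39900 nM and compound 2 at 24600 nM in this assay on the shared side chain. A modest move to a lower number is expected, estimated as a 2.2-fold lower number from compound 3 to compound 4 (0.34 log units; beyond the scatter) for this exchange. For compound 4 the estimate is 28000 nM with an expected range of 13000 nM to 58000 nM here.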

Compound 4, half-maximal inhibitory concentration: 29500 nM
For compound 4 the middle estimate is 1.1-fold (0.02 log units) below the measured one, within the range that was stated.
By their numbers in this assay, from the lowest: compounds 2, 4, 1 and 3 (each within the scatter of the next, the first and the last beyond it).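

In this assay, going by these compounds alone, (((4-methylpiperazin-1-yl)methyl)carbonyl)oxy in place of ((2-(4-methylpiperazin-1-yl)ethyl)carbonyl)amino gives the only single exchange that lies beyond the scatter: a 2.1-fold lower number from compound 3 to compound 4 (0.32 log units; beyond the scatter). With that side chain held, exchanging the group on the other ring atom stays within the scatter: a 1.2-fold higher number from compound 2 to compound 4 (0.08 log units; within the scatter), and a 1.4-fold lower number from compound 1 to compound 4 (0.13 log units; within the scatter). No supporting data on this side-chain step are available.

As far as these compounds go, the step changes the linking atom and the chain together, so their shares remain open. A ((2-(4-methylpiperazin-1-yl)ethyl)carbonyl)oxy group on the same carbon would separate them.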